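Isopropyl in Place of Phenoxy on the Amide Ring

A few compounds are considered here, and "the series" means these few. Any claim that something is new, unique, unknown or untested is made for them only; others in the source may bear on it.

Measured compounds:
- compound 1 `O=C(c1ccc(Cl)c(C(F)(F)F)c1)N1CCC(n2cncc2-c2ccc(OS(=O)(=O)c3cccc(Br)c3)cc2)CC1` gives 896 nM
- compound 2 `N#Cc1cccc(S(=O)(=O)Oc2ccc(-c3cncn3C3CCN(C(=O)c4ccc(Cl)c(C(F)(F)F)c4)CC3)cc2)c1` gives 73 nM
- compound 3 `O=C(c1ccc(Oc2ccccc2)cc1)N1CCC(n2cncc2-c2ccc(OS(=O)(=O)c3cccc4cnccc34)cc2)CC1` gives 187 nM

All three were tested in an assay on HEK293 cells for antagonist activity at P2X purinoceptor 7 (Homo sapiens), read by fluorescence, with a stated time of 2 h; a lower number here means a stronger inhibitor, a higher number a weaker inhibitor. Compound 3 stands second highest of the three numbers: compound 2 sits lower, compound 1 higher, and both gaps lie beyond the usual scatter of repeated measurements.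

Among the compounds with values here, the one step between measured compounds that differ in a single place is a 12-fold lower number from compound 1 to compound 2 (1.09 log units; beyond the scatter), a change on the ring attached to the sulfonyl group. Compound 4 `CC(C)c1ccc(C(=O)N2CCC(n3cncc3-c3ccc(OS(=O)(=O)c4cccc5cnccc45)cc3)CC2)cc1` instead changes the other end of the shared core: isopropyl in place of phenoxy on an aromatic carbon. Within the data shown here, no measured pair differs at that position, so the only known step does not bear on this change and gives no guide to its direction. With nothing to point either way, the expected outcome is a number close to that of compound 3, with no step beyond the scatter, though a real shift in either direction cannot be ruled out. On that basis compound 4 is estimated at 200 nM, within a range of 60 nM to 700 nM, which amounts to an expected step of a 1.1-fold higher number from compound 3 to compound 4 (0.03 log units; within the scatter).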

Compound 4, half-maximal inhibitory concentration: 55 nM
Compound 4: the middle estimate sits 3.6-fold (0.56 log units) above what was measured, and the stated range ends above it.
By their numbers in this assay, from the lowest: compounds 4 and 2 (each within the scatter of the next); then compound 3; then compound 1.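

In this assay, within the data shown here, the step of a 3.4-fold lower number from compound 3 to compound 4 (0.53 log units; beyond the scatter) is the first measured change on this aromatic carbon, para to a large group, and it shows that the number responds to what sits there. Phenoxy, with 7 heavy atoms, a six-membered aromatic ring and 1 hydrogen-bond acceptor, is not required for activity at this carbon: isopropyl has 3 heavy atoms, no ring and no hydrogen-bond acceptor, yet the inhibitor becomes stronger, not weaker, with the rest of the molecule unchanged. Nothing available here says which part of this exchange, the loss of the ring, the loss of the oxygen or the drop in size, accounts for the step.

Among these compounds, what remains open is how an ethyl, a tert-butyl or an amine on the same carbon would compare with isopropyl, and so whether this branched chain is special or only one of many groups that work there. As far as these compounds go, it is also open whether exchanging phenoxy for isopropyl gives a similar step when the sulfonyl group carries the cyano-bearing ring of compound 2 in place of the ring shared by compound 3 and compound 4.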